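Glycoside to aglycone: expected gain on the shared core

The source may hold more compounds than are shown below. What is called first, only, known or untested is meant among the compounds shown, and "the series" means these compounds.

Three compounds of the series have numbers in a functional assay on K562 cells (Homo sapiens) for cytotoxicity, read by spectrophotometry; a lower number here means a stronger inhibitor, a higher number a weaker inhibitor. Compound 1 `CC(=O)O[C@@]1(C)CC[C@H](O)C(C)(C)[C@@H]1CC/C(C)=C/C[C@@H](O)/C=C(\C)[C@@H](O)C[C@@H]1C(C)=CCC(=O)C1(C)C` gives 14800 nM. Compound 2 `CC(=O)O[C@@H](C[C@H]1C(C)(C)C(=O)C=C[C@]1(C)O)/C(C)=C/[C@H](O)C/C=C(\C)CC[C@H]1C(C)(C)[C@@H](O)CC[C@]1(C)OC(C)=O` gives 27500 nM in this assay; the gap to compound 1 sits within the usual scatter, so no order between the two is claimed. Compound 3 `CC(=O)O[C@@]1(C)CC[C@H](O[C@@H]2O[C@H](CO)[C@H](O)[C@H](O)[C@H]2O)C(C)(C)[C@@H]1CC/C(C)=C/C[C@@H](O)/C=C(\C)C(=O)C[C@H]1C(C)(C)C(=O)C=C[C@]1(C)O` carries the 3,4,5-trihydroxy-6-(hydroxymethyl)oxan-2-yl group on an oxygen on a saturated carbon, and in this assay it reaches only a limit, > 100000 nM. That limit, (the limit of > 100000 nM in this assay, at which 1 of the 3 values shown sits), places compound 3 weaker than both compounds with a measured number, but by an unknown amount.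

Compound 4 `CC(=O)O[C@@]1(C)CC[C@H](O)C(C)(C)[C@@H]1CC/C(C)=C/C[C@@H](O)/C=C(\C)C(=O)C[C@H]1C(C)(C)C(=O)C=C[C@]1(C)O` has not yet been measured in this assay. It differs from compound 3 in one place: hydrogen in place of 3,4,5-trihydroxy-6-(hydroxymethyl)oxan-2-yl on an oxygen on a saturated carbon. Both compounds with a measured number carry hydrogen at that oxygen, so compound 4 is expected to land near them rather than at the limit. A step beyond the scatter toward stronger inhibition is expected, an at least 5.0-fold lower number from compound 3 to compound 4 (0.69 log units; beyond the scatter), though its size can only be bounded from below since compound 3 gives no number.

For compound 4 in this assay the estimate is 20000 nM, with a range from 6000 nM to 70000 nM.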

Compound 4, half-maximal inhibitory concentration: 18900 nM
Compound 4: the middle estimate sits 1.1-fold (0.02 log units) above what was measured; the measured number falls inside the stated range.
By their numbers in this assay, from the lowest: compounds 1, 4 and 2 (each within the scatter of the next). At a limit, above all of these: compound 3.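

Hydrogen in place of 3,4,5-trihydroxy-6-(hydroxymethyl)oxan-2-yl on an oxygen on a saturated carbon gives an at least 5.2-fold lower number from compound 3 to compound 4 (0.72 log units; beyond the scatter) in this assay and so provides the first reading of this change. Before this result, no pair in the series differed in one place, so the glycoside could not be separated from the other structural differences among the compounds. The pair now fixes the direction of the change at this oxygen, but the step remains only a lower bound because compound 3 stands at a limit rather than a number: the limit of > 100000 nM in this assay, at which 1 of the 4 values shown sits.

As far as these compounds go, the size of the full step remains open, as does whether it belongs specifically to this sugar or would follow any group on that oxygen. A methyl ether, an acetate or an amine in place of the hydroxy at this carbon would test how much of the step depends on the free hydroxy and how much on the removal of the sugar.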